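A few compounds are considered here, and "the series" means these few. Any claim that something is new, unique, unknown or untested is made for them only; others in the source may bear on it.

Working notes on the series. The three measured compounds share one core and differ only in the group placed on an aromatic carbon. Compound 1 `C=CCOc1cccc(NC(=O)C2CCCN(C(=O)c3cc(C(F)(F)F)cc(C(F)(F)F)c3)C2)c1` carries allyloxy there, and in an ADME assay on PC-3 cells (Homo sapiens) for cytotoxicity, read by WST assay, tested at 100 uM (on this read-out higher numbers stand for more inhibition at the one concentration tested (going by the name of the read-out) and lower numbers for less inhibition), compound 1 gives 0%. Compound 2 `O=C(Nc1cccc(-c2cnco2)c1)C1CCCN(C(=O)c2cc(C(F)(F)F)cc(C(F)(F)F)c2)C1` carries 1,3-oxazol-5-yl, and in this assay compound 2 gives 9%. Compound 3 `O=C(Nc1cccc(Cc2ccccc2)c1)C1CCCN(C(=O)c2cc(C(F)(F)F)cc(C(F)(F)F)c2)C1` carries benzyl, and in this assay compound 3 gives 0%, level with compound 1 and together with it the lowest of the three numbers. The steps to compound 3, no change at the digits printed from compound 1 to compound 3 (within the scatter) and a number 9 percentage points lower from compound 2 to compound 3 (within the scatter), both stay within the scatter, as does a number 9 percentage points higher from compound 1 to compound 2 (within the scatter).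

Compound 4 `O=C(Nc1cccc(CN2CCCC2)c1)C1CCCN(C(=O)c2cc(C(F)(F)F)cc(C(F)(F)F)c2)C1` differs from compound 3 in one place: pyrrolidin-1-yl in place of phenyl on a saturated chain carbon bound to an aromatic carbon. Within the data shown here, no measured step swaps phenyl for pyrrolidin-1-yl, so the only guide is that every change in this region so far left this assay unmoved beyond the scatter. Compound 4 is therefore expected to show no step beyond the scatter, a number 3 percentage points higher from compound 3 to compound 4 (within the scatter). The estimate for compound 4 is 3%, expected between 0% and 15%.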

Compound 4, a percentage reported as inhibition, at one concentration (the size of the read-out at that concentration, not a potency): 51%
For compound 4 the middle estimate is 48 percentage points below the measured one; measured number above the stated range.
By their numbers in this assay, from the lowest: compounds 1, 3 and 2 (each within the scatter of the next); then compound 4.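

Of the groups on this aromatic carbon, only (pyrrolidin-1-yl)methyl moves this assay beyond the scatter, with a number 51 percentage points higher from compound 3 to compound 4 (beyond the scatter) on the swap of phenyl for pyrrolidin-1-yl at the saturated chain carbon. The other two comparisons agree, with a number 42 percentage points higher from compound 2 to compound 4 (beyond the scatter) and a number 51 percentage points higher from compound 1 to compound 4 (beyond the scatter) in the same direction, so compound 4 stands apart from all three earlier compounds, and a change of one ring on the chain carbon is enough to produce this. Nothing at hand bears on the origin of this jump.

The compounds shown leave open whether the ring or its nitrogen carries the effect: a piperidin-1-yl or morpholin-4-yl ring, or an open-chain dimethylamino group, on the same chain carbon would separate the two. Also open, from the compounds shown here alone, is whether a longer chain between the aromatic carbon and the pyrrolidin-1-yl ring keeps the effect.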